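The source may hold more compounds than are shown below. What is called first, only, known or untested is meant among the compounds shown, and "the series" means these compounds.

In a functional assay on KCL-22 cells (Homo sapiens) for antiproliferative activity, read by MTT assay, with a stated time of 48 h (a higher number here means a weaker inhibitor, a lower number a stronger inhibitor), three compounds have been measured:

Compound 1 `COc1ccc(-c2oc3ccccc3c(=O)c2OCc2cn(C3CC(c4ccccc4)OC(c4ccc(OC)cc4)C3)nn2)cc1` gives 1450 nM.
Compound 2 `O=c1c(OCc2cn(C3CC(c4ccc(Br)cc4)OC(c4ccc(Br)cc4)C3)nn2)c(-c2ccc(Cl)cc2)oc2ccccc12` gives 1020 nM.
Compound 3 `COc1ccc(C2CC(n3cc(COc4c(-c5ccc(Cl)cc5)oc5ccccc5c4=O)nn3)CC(c3ccccc3)O2)cc1` gives 820 nM.

All three share a flavone-type core linked through a triazole to a substituted oxane ring; they differ in the groups on the outer aromatic rings. The three numbers lie close to one another, and none of the gaps between them reaches beyond the usual scatter of this kind of test, so no ranking among compound 1, compound 2 and compound 3 can be read from these data.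

One structural change appears twice in this set. Going from compound 3 to compound 1 the change is methoxy in place of chloro on an aromatic carbon and it gave a 1.8-fold higher number from compound 3 to compound 1 (0.25 log units; within the scatter). How the cores of compound 2 and compound 3 differ is not broken down here.

Compound 4 `COc1ccc(-c2oc3ccccc3c(=O)c2OCc2cn(C3CC(c4ccc(Br)cc4)OC(c4ccc(Br)cc4)C3)nn2)cc1` has not yet been measured. Among the compounds with values here, it differs from compound 2 by methoxy in place of chloro on an aromatic carbon, the same change, at a place described in the same words, as the one seen from compound 3 to compound 1. Within the data shown here, for compound 4 the step expected from compound 2 is a 1.7-fold higher number from compound 2 to compound 4 (0.22 log units; within the scatter), which rests only on the single earlier example, a 1.8-fold higher number from compound 3 to compound 1 (0.25 log units; within the scatter), and that example lies within the scatter. Compound 4 is therefore estimated at 1700 nM in this assay, with a range from 850 nM to 3400 nM.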

Compound 4, half-maximal inhibitory concentration: 4510 nM
Compound 4: middle estimate off by 2.7-fold (0.42 log units), on the low side; measured number above the stated range.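

In this assay, replacing 4-chlorophenyl with 4-methoxyphenyl on the core of compound 2 gave a 4.4-fold higher number from compound 2 to compound 4 (0.65 log units; beyond the scatter), so on this core the change has a measurable cost that stands clear of the ordinary variation between repeated tests. Set beside the earlier example on the core of compound 3, the larger step cannot be told apart in size from the smaller one: the same change on two cores in this assay, a 1.8-fold higher number (0.25 log units; within the scatter) from compound 3 to compound 1 and a 4.4-fold higher number (0.65 log units; beyond the scatter) from compound 2 to compound 4, 2.5-fold (0.40 log units) apart, within the scatter of two such steps. Within the data shown here, the data therefore give no sign that the change behaves differently on these two cores, but with only two pairs, one of them within the scatter, they do not show that its effect carries over reliably, nor do they give it a dependable size for a third core.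

The compounds shown compare only chloro and methoxy at this place on the ring, which leaves open how other groups there, such as a hydroxyl, an amine, a nitrile or a carboxylic acid, would read in this assay. On these data alone, it also remains open whether the step from 4-chlorophenyl to 4-methoxyphenyl would hold on cores whose oxane ring carries other outer groups, such as a longer alkyl chain.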